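The source may report more compounds than this note shows. Statements on the series, on what has been measured and on what is new or still open speak of the compounds shown alone.

Measured compounds: compound 1 `CCN1CCN(c2cc(C)c3cc(NC(=O)c4ccccc4)ccc3n2)CC1`, 18400 nM; compound 2 `CCNc1cc(C)c2cc(NC(=O)c3ccc(Cl)c(Cl)c3)ccc2n1`, 28200 nM; compound 3 `Cc1cc(N2CCCCC2)nc2ccc(NC(=O)c3ccc(Cl)c(Cl)c3)cc12`, 42500 nM.

In a functional assay on SK-BR-3 cells (Homo sapiens) for antiproliferative activity, read by MTT assay, with a stated time of 72 h (a higher number here means a weaker inhibitor, a lower number a stronger inhibitor), compound 1 gives 18400 nM. Compound 2 gives a number within the scatter of it, whereas compound 3 lies beyond the scatter, higher than compound 1. The only single-point step among these three is a 1.5-fold higher number from compound 2 to compound 3 (0.18 log units; within the scatter), which changes the amine end of the shared core.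

Compound 4 `CCN1CCN(c2cc(C)c3cc(NC(=O)c4ccccc4OC)ccc3n2)CC1` differs from compound 1 by methoxy in place of hydrogen on an aromatic carbon. No measured step touches the benzoyl ring, so nothing shown bears on this change. The expected step is therefore a 1.0-fold lower number from compound 1 to compound 4 (0.01 log units; within the scatter), none beyond the scatter. Compound 4 is estimated at 18000 nM, between 7000 nM and 45000 nM.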

Compound 4, half-maximal inhibitory concentration: 15700 nM
Compound 4: the middle estimate sits 1.1-fold (0.06 log units) above what was measured, and the stated range covers the measured number.
By their numbers in this assay, from the lowest: compounds 4, 1, 2 and 3 (each within the scatter of the next, the first and the last beyond it).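

In this assay, for the compounds shown here, methoxy in place of hydrogen on an aromatic carbon of the benzoyl ring, ortho to a large group, gives the first measured step at this ring (a 1.2-fold lower number from compound 1 to compound 4 (0.07 log units; within the scatter)). The step lies within the scatter, so this position accepts methoxy with no change that this read-out can resolve. No evidence bears on this result.

The compounds shown leave open whether an amine, a carboxylic acid or a chlorine at this same place would behave likewise. They also leave open whether methoxy on another carbon of this ring would do so.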